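Benzyl variation on a shared core: cytotoxicity working notes

This account rests on a few compounds, and the source may have more. Where it says the series, first, only, none or still open, it means among the compounds named here.

Measured so far in a functional assay on MDA-MB-231 cells (Homo sapiens) for cytotoxicity, read by MTT assay, with a stated time of 48 h; on this read-out higher numbers stand for weaker inhibition and lower numbers for stronger inhibition:
Compound 1 `O=c1ccoc2cc(OCc3cn(Cc4cccc(F)c4)nn3)ccc12` gives > 100000 nM, a limit of the assay and not a number.
Compound 2 `O=c1ccoc2cc(OCc3cn(Cc4ccccc4Br)nn3)ccc12` gives > 100000 nM, again a limit.
Compound 3 `Cc1ccccc1Cn1cc(COc2ccc3c(=O)ccoc3c2)nn1` gives > 100000 nM, again a limit.

Compound 1 therefore stands nowhere in particular on the numbers shown: all three measured compounds sit at the same limit, and none gives a readable half-maximal inhibitory concentration. Among the measured compounds shown here, the step that the two limits leave unreadable from compound 1 to compound 2 and the step that the two limits leave unreadable from compound 1 to compound 3 are both unreadable for that reason, as is a step that the two limits leave unreadable from compound 2 to compound 3; the only evidence on the series is the limit of > 100000 nM in this assay, at which 3 of the 3 values shown sit.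

Compound 4 `O=c1ccoc2cc(OCc3cn(Cc4ccc(Cl)cc4)nn3)ccc12` is the next variation on the same position. Its difference from compound 1 is 4-chlorophenyl in place of 3-fluorophenyl on a saturated chain carbon bound to an aromatic nitrogen. The measured steps that bear on it are the two changes of the same benzyl group already seen, from compound 1 to compound 2 and from compound 1 to compound 3, and both were left unreadable by the limits. For the measured compounds named here, no measured step points to a gain in this assay from any change of the benzyl group, so no step beyond the scatter is expected; compound 4 is expected to sit at the limit as well, with a step that the limit leaves unreadable from compound 1 to compound 4 as the estimated step.

For compound 4 the estimate in this assay is 150000 nM, with a range from 50000 nM to 500000 nM.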

Compound 4, half-maximal inhibitory concentration: > 100000 nM
Compound 4 was reported as a limit (the forecaster's own chance of this, stated with the estimate: 85%); the middle value does not contradict the limit.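

In this assay compound 4 gives > 100000 nM, a limit of the assay and not a number. Among the compounds shown here, no step between compound 4 and compound 1, compound 2 or compound 3 can be read. The compounds shown leave open whether any benzyl variation on the shared core reaches a readable half-maximal inhibitory concentration in this assay.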